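Moving the ring nitrogen in an alpha-1 antagonist series

The compounds below may be only part of what the source reports. "The series", "measured", "known", "first", "only" and "open" are said of these compounds alone.

Compound 2 `COc1ccc(Cl)cc1N1CCN(CCNC(=O)c2ccncc2)CC1` and compound 1 `COc1ccc(Cl)cc1N1CCN(CCNC(=O)c2cccnc2)CC1` share one core and differ only in the ring attached to the carbonyl. In a functional assay for antagonist activity at Adrenergic receptor alpha-1 (Rattus norvegicus) (on this read-out higher numbers stand for weaker binding and lower numbers for tighter binding), compound 2 gives 66.1 nM, while compound 1 gives 2750 nM; the change, (pyridin-3-yl in place of pyridin-4-yl on a carbonyl carbon), produces a 42-fold higher number from compound 2 to compound 1 (1.62 log units; beyond the scatter). Compound 3 `Cc1ccc(N2CCN(CCNC(=O)c3ccncc3)CC2)c(C)c1` carries a different core; how that core differs from the core of compound 2 is not broken down here. In this assay compound 3 gives 85.1 nM, close to compound 2. Compound 4 `Cc1ccc(N2CCN(CCNC(=O)c3cccnc3)CC2)c(C)c1` applies the same change to compound 3, (pyridin-3-yl in place of pyridin-4-yl on a carbonyl carbon), at the same place. Within the data shown here, because the same change earlier gave a 42-fold higher number from compound 2 to compound 1 (1.62 log units; beyond the scatter), compound 4 is expected to show a 29-fold higher number from compound 3 to compound 4 (1.47 log units; beyond the scatter), an estimated 2500 nM, likely between 500 nM and 12000 nM, with the wide range reflecting that only one earlier example supports it.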

Compound 4, dissociation constant: 1150 nM
Compound 4: middle estimate off by 2.2-fold (0.34 log units), on the high side; measured number inside the range.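

In this assay, putting pyridin-3-yl in place of pyridin-4-yl on the carbonyl carbon again gives a large change, a 14-fold higher number from compound 3 to compound 4 (1.13 log units; beyond the scatter) on the second core, so the direction of the change carries over. The size of the step does not carry over unchanged, and the gap is larger than repeated measurements would explain: the same change on two cores in this assay, a 42-fold higher number (1.62 log units; beyond the scatter) from compound 2 to compound 1 and a 14-fold higher number (1.13 log units; beyond the scatter) from compound 3 to compound 4, 3.1-fold (0.49 log units) apart, beyond the scatter of two such steps. Among these compounds, with only two cores, this shows that the change can weaken binding on both without losing a fixed amount; it does not show why the sizes differ or how a third core would respond.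

As far as these compounds go, it remains open how a plain phenyl group on the carbonyl carbon would compare with either pyridine. The effect of a longer chain on this step is also unknown.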